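This account rests on a few compounds, and the source may have more. Where it says the series, first, only, none or still open, it means among the compounds named here.

Measured compounds:
compound 1 `COCC(=O)N1C[C@@H](C)N(c2ncc3[nH]nc(-c4ccc(N5CCN[C@H](C)C5)nc4)c3n2)[C@@H](C)C1` — in an assay on HeLa cells for inhibition of activin receptor type-1 (Homo sapiens), read by HTRF, with stated times of 1 h and 30 min (a lower number here means a stronger inhibitor, a higher number a weaker inhibitor), compound 1 gives 346 nM
compound 2 `C[C@@H]1CN(c2ccc(-c3n[nH]c4cnc(N5[C@H](C)CCC[C@@H]5C)nc34)cn2)CCN1` — in this assay compound 2 gives 384 nM

Among the measured compounds shown here, only two numbers are known, and compound 1 and compound 2 lie within the scatter of each other, so neither can be set apart. Compound 3 `CCOC(=O)N1C[C@@H](C)N(c2ncc3[nH]nc(-c4ccc(N5CCN[C@H](C)C5)nc4)c3n2)[C@@H](C)C1` is not yet measured; it carries ethoxy in place of methoxymethyl on a carbonyl carbon, the same atoms joined differently. For the measured compounds named here, no measured pair shows a change of this kind, so there is no step to lean on. The expectation is that compound 3 stays close to compound 1, with no move beyond the scatter, and the estimated step is a 1.2-fold higher number from compound 1 to compound 3 (0.06 log units; within the scatter). The estimate for compound 3 in this assay is 400 nM, in the range 170 nM to 950 nM.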

Compound 3, half-maximal inhibitory concentration: 212 nM
The estimate for compound 3 lay 1.9-fold (0.28 log units) above the measured number, and the stated range covers the measured number.
By their numbers in this assay, from the lowest: compounds 3, 1 and 2 (each within the scatter of the next).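

On a carbonyl carbon whose other neighbours are an amide-type nitrogen in a ring, ethoxy in place of methoxymethyl gives a 1.6-fold lower number from compound 1 to compound 3 (0.21 log units; within the scatter) in this assay for this pair. The position therefore accepts this rearrangement of the same atoms without a change that can be told from the scatter, though one pair sets no trend. Nothing available bears on a reason for this result.

Still open, on these data alone, is whether a longer chain such as butoxy, or an amine such as dimethylamino, on this carbonyl carbon would move the number beyond the scatter.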